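Amide substituent series: the step to compound 4

This account rests on a few compounds, and the source may have more. Where it says the series, first, only, none or still open, it means among the compounds named here.

Measured compounds and their numbers:
compound 1 `COc1cc2c(cc1OC)C(CC(N)=O)CC2` gives 31%
compound 2 `CCN(CC)C(=O)CC1CCc2cc(OC)c(OC)cc21` gives 40%
compound 3 `CCCNC(=O)CC1CCc2cc(OC)c(OC)cc21` gives 28%

All three numbers come from a functional assay on the whole organism (strain Wistar) for inhibition, with Rattus norvegicus as the target, read by paw edema, with stated times of 60 min and 2 h, at a dose of 100 mg/kg by the oral route; on this read-out higher numbers stand for more inhibition at the one dose given (going by the name of the read-out) and lower numbers for less inhibition. Compound 3 stands lowest of the three. Its nearest neighbour is compound 1, and the two lie within the scatter of each other; compound 2 sits furthest away, beyond the scatter: a number 12 percentage points lower from compound 2 to compound 3 (beyond the scatter). The other step that reaches compound 3, a number 3 percentage points lower from compound 1 to compound 3 (within the scatter), is within the scatter, as is a number 9 percentage points higher from compound 1 to compound 2 (within the scatter) between the two other amides.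

Compound 4 `CCCCNC(=O)CC1CCc2cc(OC)c(OC)cc21` differs from compound 3 by methyl in place of hydrogen on a saturated chain carbon, three bonds along the chain from an amide-type nitrogen. Going by the values given here, no measured pair repeats this change. Among the compounds with values here, the steps that bear on it are the two that alter the group on the amide nitrogen: the small one, a number 3 percentage points lower from compound 1 to compound 3 (within the scatter), and the modest one, a number 12 percentage points lower from compound 2 to compound 3 (beyond the scatter). Both vary the amide substituent more widely than the present change does, and one of them stays within the scatter. A step no larger than the scatter is therefore expected in this assay, in no settled direction.

The expected step is a number 2 percentage points higher from compound 3 to compound 4 (within the scatter). Compound 4 is estimated at 30%, with a range from 15% to 45%.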

Compound 4, a percentage reported as inhibition, in the whole organism at one dose (the size of the read-out at that dose, not a potency): 24%
Beside the measured number, compound 4's estimate is 6 percentage points above it; low and high end bracket the measured number.
By their numbers in this assay, from the lowest: compounds 4, 3, 1 and 2 (each within the scatter of the next, the first and the last beyond it).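

Going from propyl to butyl on the amide nitrogen puts methyl in place of hydrogen on a saturated chain carbon, three bonds along the chain from an amide-type nitrogen, and in this assay this gives a number 4 percentage points lower from compound 3 to compound 4 (within the scatter), so at this position the added methyl produces no step that can be told from the scatter. Butyl in place of hydrogen on the amide nitrogen also stays within the scatter, with a number 7 percentage points lower from compound 1 to compound 4 (within the scatter), whereas butylamino in place of diethylamino gives a number 16 percentage points lower from compound 2 to compound 4 (beyond the scatter), so compound 2 stands beyond the scatter of compound 4 as it does of compound 3, while remaining within the scatter of compound 1.

On these data alone, whether a longer chain on the amide nitrogen, such as hexyl or octyl, would carry the number beyond the scatter remains open. So does the effect of an amine or a carboxylic acid at the far end of that chain, or of a single branched group such as isopropyl or tert-butyl on the same nitrogen. Nothing available on this series accounts for any of these steps.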